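This account rests on a few compounds, and the source may have more. Where it says the series, first, only, none or still open, it means among the compounds named here.

Compound 2 `CCCc1nc(C)c2c(C)nn(CC(=O)OCC)c(=O)n12` stands at the edge of what the study could measure. In a functional assay for inhibition, with Homo sapiens as the target (on this read-out lower numbers stand for stronger inhibition and higher numbers for weaker inhibition), compound 2 gives only a limit, > 48000 nM. Its parent, compound 1 `CCCc1nc(C)c2cnn(CC(=O)OCC)c(=O)n12`, also returns only a limit in this assay, > 48000 nM. Compound 3 `CCCc1nc(C)c2cnnc(SCC(=O)OCC)n12` likewise gives only a limit, > 48000 nM. The step that the two limits leave unreadable from compound 1 to compound 2 is therefore unreadable because of the limit of > 48000 nM in this assay, at which 3 of the 3 values shown sit. Compound 4 `C=C=Cn1nc(C)c2c(C)nc(CCC)n2c1=O` differs from compound 2 by propa-1,2-dien-1-yl in place of (ethoxycarbonyl)methyl on an aromatic nitrogen: propa-1,2-dien-1-yl enters where (ethoxycarbonyl)methyl leaves. Among the compounds with values here, no measured step bears on this exchange, and the three limits give no direction. Compound 4 is thus expected to show a step of a number no higher from compound 2 to compound 4 (the limit leaves the size open) of no readable size. The estimate for compound 4 is 48000 nM, within 8000 nM to 300000 nM.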

Compound 4, half-maximal inhibitory concentration: > 48000 nM
Compound 4: no number, only a limit; the forecaster's own chance of this, stated with the estimate: 75%; the middle value lies on the limit itself.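

No step can be read from compound 2 to compound 4, because both return only a limit: the limit of > 48000 nM in this assay, at which 4 of the 4 values shown sit. The compounds shown leave open how strongly any of them inhibits in this assay and what either exchange does.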